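Moving the carboxylic acid around the terminal ring

This account rests on a few compounds, and the source may have more. Where it says the series, first, only, none or still open, it means among the compounds named here.

Measured so far:
compound 1 `Cc1c(OCCCCOc2ccc(C(=O)O)cc2F)ccc(C(=O)CC(C)C)c1O` — 102 nM
compound 2 `Cc1ccc(C(=O)O)cc1OCCCCOc1ccc(C(=O)CC(C)C)c(O)c1C` — 454 nM

In an assay on HEK293 cells for positive allosteric modulation of metabotropic glutamate receptor 2 (Rattus norvegicus), read by thallium flux, with a stated time of 2.5 min (a lower number here means that less compound is needed, a higher number that more compound is needed for the effect), compound 2 gives the highest of the two numbers, with compound 1 giving a 4.5-fold higher number from compound 1 to compound 2 (0.65 log units; beyond the scatter) when 5-carboxy-2-methylphenyl replaces 4-carboxy-2-fluorophenyl. Compound 3 `Cc1cc(OCCCCOc2ccc(C(=O)CC(C)C)c(O)c2C)ccc1C(=O)O` carries the same atoms arranged differently: 4-carboxy-3-methylphenyl in place of 5-carboxy-2-methylphenyl on an oxygen on a saturated carbon. Within the data shown here, no measured step covers this exact change; only the step from compound 1 to compound 2 bears on it, and compound 3 shares the 4-carboxy arrangement of compound 1's group. A modest drop is therefore expected, a 2.3-fold lower number from compound 2 to compound 3 (0.36 log units; beyond the scatter), giving compound 3 an estimated 200 nM (range 70 nM to 700 nM).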

Compound 3, half-maximal effective concentration: 173 nM
Compound 3: the middle estimate sits 1.2-fold (0.06 log units) above what was measured; the range from low to high includes it.
By their numbers in this assay, from the lowest: compounds 1 and 3 (each within the scatter of the next); then compound 2.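

Rearranging the same atoms from 5-carboxy-2-methylphenyl to 4-carboxy-3-methylphenyl gives a 2.6-fold lower number from compound 2 to compound 3 (0.42 log units; beyond the scatter) and shows that the arrangement on this ring alone can shift the number. Replacing 4-carboxy-2-fluorophenyl with 4-carboxy-3-methylphenyl gives a 1.7-fold higher number from compound 1 to compound 3 (0.23 log units; within the scatter) and leaves these two groups indistinguishable here. No available measurement explains either step.

Still open, going by these compounds, is whether the carboxylic acid itself is needed, or whether an amide or a tetrazole could stand in its place. Also open, on these data alone, is how a chlorine or a methoxy group would compare with the methyl.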